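The source may report more compounds than this note shows. Statements on the series, on what has been measured and on what is new or still open speak of the compounds shown alone.

Working notes on the series. Compound 1 `CS(=O)(=O)c1ccc(-c2cnc3[nH]cc(-c4nnc(-c5ccc(F)cc5)o4)c(=O)c3c2)cc1` gives 39.5% in a functional assay on HCT-116 cells (Homo sapiens) for positive allosteric modulation, read by MTT assay, with stated times of 24 h and 48 h, tested at 2.5 uM; on this read-out lower numbers stand for less inhibition of growth and higher numbers for more inhibition of growth at the one concentration tested; compound 2 `CS(=O)(=O)c1ccc(-c2cnc3[nH]cc(-c4nnc(-c5ccc(Cl)cc5)o4)c(=O)c3c2)cc1` gives 24.9%; compound 3 `CS(=O)(=O)c1ccc(-c2cnc3[nH]cc(-c4nnc(-c5cccnc5)o4)c(=O)c3c2)cc1` gives 28.6%. Compound 3 stands second highest of the three: its gap to compound 2 lies within the scatter, whereas a number 10.9 percentage points lower from compound 1 to compound 3 (beyond the scatter) lies beyond it. Compound 4 `Cc1cccc(-c2nnc(-c3c[nH]c4ncc(-c5ccc(S(C)(=O)=O)cc5)cc4c3=O)o2)c1` carries 3-methylphenyl in place of pyridin-3-yl on an aromatic carbon. The measured steps that bear on this are a number 14.6 percentage points lower from compound 1 to compound 2 (beyond the scatter), a number 10.9 percentage points lower from compound 1 to compound 3 (beyond the scatter) and a number 3.7 percentage points higher from compound 2 to compound 3 (within the scatter). None of them exchanges a pyridin-3-yl for a methyl-bearing phenyl; the nearest comparison is compound 1 against compound 3, where the carbon-only ring gave the higher number. A small upward step is therefore expected, a number 4.4 percentage points higher from compound 3 to compound 4 (within the scatter), not clearly beyond the scatter. Compound 4 is estimated at 33%, with a range of 18% to 48%.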

Compound 4, percent growth inhibition at one concentration: 50.8%
Compound 4: middle estimate off by 17.8 percentage points, on the low side; measured number outside the range, above it.
By their numbers in this assay, from the lowest: compounds 2 and 3 (each within the scatter of the next); then compound 1; then compound 4.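

The 3-methylphenyl group lifts the number well past anything the earlier groups gave at this position on the five-membered aromatic ring: a number 22.2 percentage points higher from compound 3 to compound 4 (beyond the scatter) and also a number 25.9 percentage points higher from compound 2 to compound 4 (beyond the scatter) and a number 11.3 percentage points higher from compound 1 to compound 4 (beyond the scatter) on the halogen-bearing rings. A carbon-only ring alone does not account for this, since compound 2 has one and lies within the scatter of compound 3. No measurement at hand explains the step. 

From the compounds shown here alone, whether the methyl group itself carries the gain stays open, and so does the response to an unsubstituted phenyl, a methoxyphenyl or an aminophenyl here.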